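Fluoro in place of methoxy on compound 3

The compounds below may be only part of what the source reports. "The series", "measured", "known", "first", "only" and "open" are said of these compounds alone.

Among the compounds with values here, in an ADME assay on HeLa cells (Homo sapiens) for cytotoxicity, read by crystal violet staining, with a stated time of 72 h (on this read-out lower numbers stand for higher toxicity in this test and higher numbers for lower toxicity in this test), compound 3 `COc1cc(-c2noc(C(F)(F)F)n2)ccc1OCCCc1cc(C(=O)N(C)C)no1` gives 68000 nM, the only actual number in this small set. Compound 1 `CCOC(=O)c1cc(CCCOc2ccc(-c3noc(C(F)(F)F)n3)cc2OC)on1` gives > 100000 nM, which is a limit of the assay and not a number. Compound 2 `Cc1cc(-c2noc(C(F)(F)F)n2)cc(C)c1OCCCc1cc(-c2ccc(OC(F)(F)F)cc2)no1` gives > 100000 nM, which is likewise a limit. The set is therefore dominated by the limit of > 100000 nM in this assay, at which 2 of the 3 values shown sit.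

Compound 4 `CN(C)C(=O)c1cc(CCCOc2ccc(-c3noc(C(F)(F)F)n3)cc2F)on1` differs from compound 3 in one place: fluoro in place of methoxy on an aromatic carbon. This swap sits ortho to a large group.

Within the data shown here, the only measured step is an at least 1.4-fold lower number from compound 1 to compound 3 (0.16 log units; that floor lies within the scatter). It is a change of dimethylamino in place of ethoxy on a carbonyl carbon, elsewhere in the molecule, so it offers no direct guide to this swap. No step beyond the scatter is therefore expected in this assay, and no direction can be favoured. The expected step is a 1.0-fold higher number from compound 3 to compound 4 (0.01 log units; within the scatter). For compound 4 the estimate is 70000 nM, with an expected range of 30000 nM to 100000 nM.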

Compound 4, half-maximal cytotoxic concentration: 20200 nM
For compound 4 the middle estimate is 3.5-fold (0.54 log units) above the measured one; measured number outside the range, below it.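

In this assay, replacing methoxy with fluoro on this aromatic carbon, ortho to a large group, gives a 3.4-fold lower number from compound 3 to compound 4 (0.53 log units; beyond the scatter). Here a lower number stands for higher toxicity in this test, so this position can shift the read-out, which the earlier step could not show: an at least 1.4-fold lower number from compound 1 to compound 3 (0.16 log units; that floor lies within the scatter) was made elsewhere in the molecule, and its floor lies within the scatter. Within the data shown here, this is still only one readable change, in a set where few values are true numbers: the limit of > 100000 nM in this assay, at which 2 of the 4 values shown sit.

On these data alone, it remains open whether the shift follows from losing methoxy or from gaining fluoro, which chloro, hydroxy or plain hydrogen on the same carbon could help separate. As far as these compounds go, it is also open whether the same swap acts alike when an ethoxy group replaces the dimethylamino on the carbonyl carbon.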